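A Methoxycarbonyl Group Added to the Core of Compound 2

The compounds below may be only part of what the source reports. "The series", "measured", "known", "first", "only" and "open" are said of these compounds alone.

Compound 1 `O=C1NC(=O)c2c(NCc3ccccc3[N+](=O)[O-])cccc21` gives > 100000 nM in an assay for inhibition of Tryptophan 2,3-dioxygenase (Homo sapiens), with stated times of 10 min and 60 min; on this read-out higher numbers stand for weaker inhibition and lower numbers for stronger inhibition.
Compound 2 `O=[N+]([O-])c1ccccc1CNc1cccc2[nH]ncc12` gives 17000 nM in this assay.
Compound 3 `O=[N+]([O-])c1ccc(CNc2cc(Br)cc3[nH]ncc23)cc1` gives 2230 nM in this assay.

Among the two compounds that return a number, compound 2 stands highest. Going by the values given here, compound 3 gives a lower number, and the gap between the two lies beyond the usual scatter; since the two differ in more than one place, the data show only these two values and no single step. Compound 1 gives only a limit, not a number, as the first line shows (the limit of > 100000 nM in this assay, at which 1 of the 3 values shown sits).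

Compound 4 `COC(=O)c1cc(NCc2ccccc2[N+](=O)[O-])c2cn[nH]c2c1` is the unmeasured compound and follows from compound 2 by one change: methoxycarbonyl in place of hydrogen on an aromatic carbon. Among the compounds with values here, no measured pair tells how such an addition moves the read-out, and the two numbered compounds differ from one another in other places. Compound 4 is therefore expected to stay close to compound 2, with a step from compound 2 to compound 4 of a 1.4-fold lower number from compound 2 to compound 4 (0.15 log units; within the scatter), within the scatter. For compound 4 the estimate is 12000 nM, with a range from 3000 nM to 50000 nM.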

Compound 4, half-maximal inhibitory concentration: > 100000 nM
Compound 4: only a limit was reported (the forecaster's own chance of this, stated with the estimate: 15%); at least 8.3-fold (0.92 log units) between middle value and limit.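

Methoxycarbonyl in place of hydrogen on this aromatic carbon gives the first single change that can be read in this assay, and it weakens inhibition, with an at least 5.8-fold higher number from compound 2 to compound 4 (0.76 log units; beyond the scatter). Compound 4 gives only a limit, > 100000 nM. The step therefore fixes only a smallest size, because the read-out of compound 4 stops at a limit: the limit of > 100000 nM in this assay, at which 2 of the 4 values shown sit.

The compounds shown leave open whether this carbon tolerates other groups, such as a methyl group, an amine or a carboxylic acid, or whether any addition there weakens inhibition to a similar degree. They also leave open how far the true value of compound 4 lies from the limit, and whether methoxycarbonyl on another carbon of the shared core would read the same way.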